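The compounds below may be only part of what the source reports. "The series", "measured", "known", "first", "only" and "open" are said of these compounds alone.

Measured so far in an ADME assay on MDCK cells (Canis lupus familiaris) for cytotoxicity, read by CellTiter-Glo, with a stated time of 10 min; on this read-out higher numbers stand for lower toxicity in this test and lower numbers for higher toxicity in this test:
compound 1 `NC(=O)c1nccc([C@@H]2O[C@H](CO)[C@@H](O)[C@H]2O)c1O` gives 2000 nM
compound 2 `NC(=O)c1nccc([C@@H]2O[C@H](CO)[C@@H](O)[C@H]2O)c1F` gives a limit only, > 400000 nM

Compound 2 therefore sits at the limit of > 400000 nM in this assay, at which 1 of the 2 values shown sits, the highest number shown and the lower-toxicity end of this set. Among the measured compounds shown here, the only measured step, an at least 200-fold higher number from compound 1 to compound 2 (2.30 log units; beyond the scatter), concerns the same exchange at a different place. Compound 3 `NC(=O)c1nccc([C@@H]2O[C@H](CO)[C@@H](O)[C@H]2F)c1F` differs from compound 2 by fluoro in place of hydroxy on a saturated ring carbon. The measured step bears on it only by analogy; with compound 2 already at the limit, no step beyond the scatter is expected in this assay, so the estimate means a number no higher from compound 2 to compound 3 (the limit leaves the size open). For compound 3 the expected value is 400000 nM, in the range 100000 nM to 2000000 nM, most probably again reported only as a limit.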

Compound 3, half-maximal cytotoxic concentration: 306000 nM
For compound 3 the middle estimate is 1.3-fold (0.12 log units) above the measured one; low and high end bracket the measured number.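

In this assay, fluoro in place of hydroxy on this saturated ring carbon gives an at least 1.3-fold lower number from compound 2 to compound 3 (0.11 log units; that floor lies within the scatter). Compound 3 gives 306000 nM, so this exchange on the ring now has a measured number at its far end, and no step beyond the scatter can be claimed for it. Compound 2 stands only as a limit, so the true size of the step stays open: the limit of > 400000 nM in this assay, at which 1 of the 3 values shown sits.

As far as these compounds go, how an amine or a methoxy group on this ring carbon would read remains open. From the compounds shown here alone, the effect of fluoro in place of the other ring hydroxy group also remains open.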